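A level set of three, and compound 4

This account rests on a few compounds, and the source may have more. Where it says the series, first, only, none or still open, it means among the compounds named here.

In a functional assay on HepG2 cells (Homo sapiens) for inhibition, read by MTT assay, with a stated time of 48 h (a higher number here means a weaker inhibitor, a lower number a stronger inhibitor), compound 1 `CS(=O)(=O)Nc1ccc(-n2cc(-c3ccccc3)nn2)cc1Oc1ccccc1` gives 13600 nM, compound 2 `Cc1ccc(OCc2cn(-c3ccc(NS(C)(=O)=O)c(Oc4ccccc4)c3)nn2)cc1` gives 13000 nM and compound 3 `CS(=O)(=O)Nc1ccc(-n2cc(OCc3ccccc3)nn2)cc1Oc1ccccc1` gives 12300 nM. Compound 2 lies within the scatter of both others, so the three compounds sit at one level. The next compound, compound 4 `CS(=O)(=O)Nc1ccc(-n2cc(COc3ccc4ccccc4c3)nn2)cc1Oc1ccccc1`, differs from compound 2 as follows: naphthalen-2-yl in place of 4-methylphenyl on an oxygen on a saturated carbon. In words, naphthalen-2-yl stands in place of 4-methylphenyl on an oxygen on a saturated carbon. Among the compounds with values here, three measured steps bear on this change, since each exchanges the group on the aromatic carbon: a 1.0-fold lower number from compound 1 to compound 2 (0.02 log units; within the scatter), a 1.1-fold lower number from compound 1 to compound 3 (0.04 log units; within the scatter) and a 1.1-fold lower number from compound 2 to compound 3 (0.02 log units; within the scatter). All three stay within the scatter. None of them swaps 4-methylphenyl for naphthalen-2-yl, so they are indirect evidence only. On that evidence, no step beyond the scatter is expected in this assay. The expected step is a 1.2-fold lower number from compound 2 to compound 4 (0.07 log units; within the scatter). For compound 4 the estimate is 11000 nM, with an expected range of 5500 nM to 22000 nM.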

Compound 4, half-maximal inhibitory concentration: 19500 nM
The estimate for compound 4 lay 1.8-fold (0.25 log units) below the measured number, and the stated range covers the measured number.
By their numbers in this assay, from the lowest: compounds 3, 2, 1 and 4 (each within the scatter of the next).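

Within the data shown here, compound 2 and compound 4 give the first direct reading on the group carried by the oxygen on a saturated carbon, where the earlier steps had exchanged the whole group on the aromatic carbon. In this assay, naphthalen-2-yl in place of 4-methylphenyl gives a 1.5-fold higher number from compound 2 to compound 4 (0.18 log units; within the scatter), so going from one six-membered aromatic ring to 2 does not carry the number beyond the scatter. No supporting measurement is available to account for this small step.

Going by these compounds, both groups compared at this place are carbon-only aromatic systems, so it remains open whether a pyridin-3-yl or a 4-carboxyphenyl group there would shift the number beyond the scatter. The pair also cannot show whether any change at this place separates compounds in this assay.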